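The compounds below may be only part of what the source reports. "The series", "measured", "known", "first", "only" and "open" are said of these compounds alone.

In a functional assay on A549 cells (Homo sapiens) for antiproliferative activity, read by MTT assay, with a stated time of 72 h (a lower number here means a stronger inhibitor, a higher number a weaker inhibitor), compound 1 `CN1CCN(C(=S)SCc2ccc3nc(N)nc(N)c3c2)CC1` gives 9200 nM, compound 2 `Nc1nc(N)c2cc(CSC(=S)N3CCN(c4ccccc4)CC3)ccc2n1` gives 2970 nM and compound 3 `Nc1nc(N)c2cc(CSC(=S)N3CCN(c4ccccc4Cl)CC3)ccc2n1` gives 3610 nM. Compound 3 stands level with compound 2 within the scatter, and both lie under compound 1. Compound 4 `Nc1nc(N)c2cc(CSC(=S)N3CCN(c4ccc([N+](=O)[O-])cc4)CC3)ccc2n1` differs from compound 3 at the amine nitrogen in a ring: 4-nitrophenyl in place of 2-chlorophenyl on an amine nitrogen in a ring. Replacing methyl at that nitrogen gave modest steps, a 3.1-fold lower number from compound 1 to compound 2 (0.49 log units; beyond the scatter) and a 2.5-fold lower number from compound 1 to compound 3 (0.41 log units; beyond the scatter). For the measured compounds named here, the only measured change on the phenyl itself gave a 1.2-fold higher number from compound 2 to compound 3 (0.08 log units; within the scatter), within the scatter. On the strength of that one step, no change beyond the scatter is expected in this assay, and the estimated step is a 1.1-fold lower number from compound 3 to compound 4 (0.05 log units; within the scatter). For compound 4 the expected value is 3200 nM, with an estimated range of 1300 nM to 7500 nM.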

Compound 4, half-maximal inhibitory concentration: 1910 nM
Compound 4: middle estimate off by 1.7-fold (0.22 log units), on the high side; the measured number falls inside the stated range.
By their numbers in this assay, from the lowest: compounds 4, 2 and 3 (each within the scatter of the next); then compound 1.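

At the amine nitrogen in a ring, 4-nitrophenyl in place of 2-chlorophenyl (a 1.9-fold lower number from compound 3 to compound 4 (0.28 log units; within the scatter)) and nitro in place of hydrogen on the aromatic carbon (a 1.6-fold lower number from compound 2 to compound 4 (0.19 log units; within the scatter)) both stay within the scatter, so a second kind of phenyl substituent leaves the number level. Against methyl, 4-nitrophenyl gives a modest step (a 4.8-fold lower number from compound 1 to compound 4 (0.68 log units; beyond the scatter)), so all three aryl groups shown keep their numbers under compound 1. No evidence on the origin of these steps is available.

Open, from the compounds shown here alone, is whether an amine or a carboxylic acid on the phenyl would also stay level with compound 2. Also open, going by these compounds, is how a longer chain in place of the phenyl on that nitrogen would compare with compound 1.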